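The source may report more compounds than this note shows. Statements on the series, on what has been measured and on what is new or still open speak of the compounds shown alone.

Measured so far in a functional assay on HT-29 cells (Homo sapiens) for antiproliferative activity, read by MTT assay, with a stated time of 96 h; on this read-out higher numbers stand for weaker inhibition and lower numbers for stronger inhibition:
- compound 1 `NCCCCCCC(=S)N/N=C1\CC2(CCCCC2)Oc2c1ccc1ccccc21` gives 3870 nM
- compound 2 `O=C(N/N=C1\CC2(CCCCC2)Oc2c1ccc1ccccc21)Nc1ccc(Cl)cc1` gives 7370 nM

Compound 2, at 7370 nM here, has only compound 1 to stand against, and the two values lie within the scatter of each other. Going on to compound 3 `N/N=C1\CC2(CCCCC2)Oc2c1ccc1ccccc21` puts hydrogen in place of (4-chlorophenyl)carbamoyl on an amine nitrogen. Among the measured compounds shown here, one measured step bears on this: a 1.9-fold higher number from compound 1 to compound 2 (0.28 log units; within the scatter) also swaps the group on an amine nitrogen, and it stayed within the scatter. For the measured compounds named here, that step exchanged one sizeable group for another, however, and no measured compound has bare hydrogen there, so the evidence is thin. In this assay no step beyond the scatter is expected, and the estimated size is a 1.1-fold lower number from compound 2 to compound 3 (0.02 log units; within the scatter) in this case. For compound 3 the estimate is 7000 nM with a range from 2000 nM to 25000 nM as its expected bounds.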

Compound 3, half-maximal inhibitory concentration: 9970 nM
Compound 3: middle estimate off by 1.4-fold (0.15 log units), on the low side; the measured number falls inside the stated range.
By their numbers in this assay, from the lowest: compounds 1, 2 and 3 (each within the scatter of the next, the first and the last beyond it).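

In this assay, cutting the group on the amine nitrogen down to bare hydrogen gives a 1.4-fold higher number from compound 2 to compound 3 (0.13 log units; within the scatter) and so leaves compound 2 and compound 3 indistinguishable, which means the (4-chlorophenyl)carbamoyl group shows no measurable contribution of its own. Among the compounds shown here, the same hydrogen set against the ring-free group of compound 1 gives a 2.6-fold higher number from compound 1 to compound 3 (0.41 log units; beyond the scatter) and is the first step here beyond the scatter, although a modest one, so what sits on this nitrogen can matter to a small degree. No accompanying measurement offers an account of this difference.

On these data alone, it remains open which part of the group in compound 1 matters, its nitrogen or its sulfur. A shorter chain, or a carboxylic acid in place of the amine on that chain, would help to test this.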